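This account rests on a few compounds, and the source may have more. Where it says the series, first, only, none or still open, it means among the compounds named here.

Measured compounds in a functional assay on MGC-803 cells (Homo sapiens) for inhibition, read by MTT assay, with a stated time of 48 h; on this read-out higher numbers stand for weaker inhibition and lower numbers for stronger inhibition:
compound 1 `CCC/C=C/C(=O)N(Cc1ccc(OC)c(O)c1)c1cc(OC)c(OC)c(OC)c1` gives 70 nM
compound 2 `COc1ccc(CN(C(=O)CO)c2cc(OC)c(OC)c(OC)c2)cc1O` gives 160 nM
compound 3 `CCC(=O)N(Cc1ccc(OC)c(O)c1)c1cc(OC)c(OC)c(OC)c1` gives 50 nM

Compound 3 has the lowest number of the three, but its separation from compound 1 is within the scatter, a 1.4-fold lower number from compound 1 to compound 3 (0.15 log units; within the scatter), so the two cannot be ordered; only compound 2 stands apart, a 3.2-fold lower number from compound 2 to compound 3 (0.51 log units; beyond the scatter) and a 2.3-fold higher number from compound 1 to compound 2 (0.36 log units; beyond the scatter).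

Compound 4 `C=CC(=O)N(Cc1ccc(OC)c(O)c1)c1cc(OC)c(OC)c(OC)c1` has not been measured. Its change from compound 3 is vinyl in place of ethyl on a carbonyl carbon. Among the measured compounds shown here, the one step that bears on it is the chain variation from compound 1 to compound 3, where pent-1-en-1-yl gave way to ethyl with no shift beyond the scatter. A double bond outside aromatic rings is thus already present in compound 1 without cost, and the vinyl group of compound 4 is smaller still. No step beyond the scatter is expected in this assay for compound 4 in either direction. The expected step is a 1.2-fold higher number from compound 3 to compound 4 (0.08 log units; within the scatter). For compound 4 the estimate is 60 nM, with a range from 25 nM to 140 nM.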

Compound 4, half-maximal inhibitory concentration: 62 nM
Compound 4: middle estimate off by 1.0-fold (0.01 log units), on the low side; the range from low to high includes it.
By their numbers in this assay, from the lowest: compounds 3, 4 and 1 (each within the scatter of the next); then compound 2.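

In this assay, the carbonyl carbon whose other neighbour is the amide-type nitrogen takes vinyl in place of ethyl with no readable shift (a 1.2-fold higher number from compound 3 to compound 4 (0.09 log units; within the scatter)), and vinyl in place of pent-1-en-1-yl is likewise within the scatter (a 1.1-fold lower number from compound 1 to compound 4 (0.05 log units; within the scatter)), so these three groups cannot be ordered here. Hydroxymethyl remains the one group at this position that stands apart, now against vinyl as well (a 2.6-fold lower number from compound 2 to compound 4 (0.41 log units; beyond the scatter)), which adds a third comparison to the two already seen with ethyl and pent-1-en-1-yl. Nothing available explains why these steps have the sizes they do.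

Going by these compounds, whether an aminomethyl group or a carboxylic acid at this position would stay with these three groups or move as hydroxymethyl does remains open. So does the behaviour of a saturated butyl chain.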